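This account rests on a few compounds, and the source may have more. Where it says the series, first, only, none or still open, it means among the compounds named here.

Measured so far in a functional assay (trachea) with Cavia porcellus as the target; a lower number here means a stronger inhibitor, a higher number a weaker inhibitor:
compound 1 `CCn1nc(-c2cccnc2)c2ccccc2c1=O` gives 1320 nM
compound 2 `CC(C)n1nc(-c2cccnc2)c2ccccc2c1=O` gives 3090 nM
compound 3 `O=c1c2ccccc2c(-c2cccnc2)nn1Cc1cccc(Cl)c1` gives 4170 nM

Compound 2 stands second highest of the three numbers; the step of a 1.3-fold higher number from compound 2 to compound 3 (0.13 log units; within the scatter) is within the scatter, while the step of a 2.3-fold higher number from compound 1 to compound 2 (0.37 log units; beyond the scatter) is beyond it. Compound 4 `COCCn1nc(-c2cccnc2)c2ccccc2c1=O` differs from compound 2 by 2-methoxyethyl in place of isopropyl on an aromatic nitrogen. For the measured compounds named here, the steps that bear on this change are a 2.3-fold higher number from compound 1 to compound 2 (0.37 log units; beyond the scatter) and a 3.2-fold higher number from compound 1 to compound 3 (0.50 log units; beyond the scatter): each move away from the ethyl of compound 1 gave a modestly higher number in this assay. The 2-methoxyethyl of compound 4 is again a chain on that aromatic nitrogen, so the expected move from compound 2 is back toward compound 1, a modest lowering at most: a 1.7-fold lower number from compound 2 to compound 4 (0.23 log units; within the scatter). Compound 4 is estimated at 1800 nM, with a range from 800 nM to 4500 nM.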

Compound 4, half-maximal inhibitory concentration: 9330 nM
Beside the measured number, compound 4's estimate is 5.2-fold (0.71 log units) below it; the measured number lies above the stated range.
By their numbers in this assay, from the lowest: compound 1; then compounds 2 and 3 (each within the scatter of the next); then compound 4.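

In this assay the rise of a 7.1-fold higher number from compound 1 to compound 4 (0.85 log units; beyond the scatter) is the largest step in the series, and a 3.0-fold higher number from compound 2 to compound 4 (0.48 log units; beyond the scatter) together with a 2.2-fold higher number from compound 3 to compound 4 (0.35 log units; beyond the scatter) places compound 4 above all three earlier compounds. At this aromatic nitrogen, then, adding methoxy to the chain, with its one hydrogen-bond acceptor, goes with a higher number and not with a return toward compound 1. Nothing on hand accounts for this change.

The compounds shown leave open whether the higher number tracks the oxygen or the chain length. A butyl chain, a 2-hydroxyethyl group or a 2-aminoethyl group on this nitrogen would bear on that.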